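Same swap, second pair: estimating compound 4's pKa

A few compounds are considered here, and "the series" means these few. Any claim that something is new, unique, unknown or untested is made for them only; others in the source may bear on it.

Measured so far:
Compound 1 `COc1ccc(F)cc1CNCCCNc1ccnc2cc(Cc3ccc(C#N)cc3)ccc12`: 9.47
Compound 2 `COc1ccc(Oc2ccc3c(NCCCNCc4cc(F)ccc4OC)ccnc3c2)cc1`: 9.28
Compound 3 `COc1ccc(Oc2ccc3c(NCCCNCc4ccco4)ccnc3c2)cc1`: 9.28

In a physicochemical assay for acid dissociation, compound 1 gives 9.47, compound 2 gives 9.28 and compound 3 gives 9.28. Compound 2 and compound 3 are told apart by furan-2-yl in place of 5-fluoro-2-methoxyphenyl on a saturated chain carbon bound to an amine nitrogen, and that change gave no change at the digits printed from compound 2 to compound 3 (within the scatter). Compound 1 differs from compound 2 by 4-cyanobenzyl in place of 4-methoxyphenoxy on an aromatic carbon, a change that gave a number 0.19 log units higher from compound 2 to compound 1 (within the scatter).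

Compound 4 `N#Cc1ccc(Cc2ccc3c(NCCCNCc4ccco4)ccnc3c2)cc1` has not yet been measured. It differs from compound 3 by 4-cyanobenzyl in place of 4-methoxyphenoxy on an aromatic carbon, the same change seen from compound 2 to compound 1, at a place described in identical words, so the two pairs share the same change on cores that differ by what is set out between compound 2 and compound 3. Going by the values given here, with that earlier step as the only guide, compound 4 is expected to follow compound 3 by a number 0.19 log units higher from compound 3 to compound 4 (within the scatter) in this assay. Compound 4 is therefore estimated at 9.47, with a likely range from 9.2 to 9.75.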

Compound 4, acid dissociation constant: 9.47
Compound 4: middle estimate and measured number agree at the digits printed; the range from low to high includes it.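

In this assay, 4-cyanobenzyl in place of 4-methoxyphenoxy gave a number 0.19 log units higher from compound 3 to compound 4 (within the scatter) on the core carrying furan-2-yl, the same size as a number 0.19 log units higher from compound 2 to compound 1 (within the scatter) on the core carrying 5-fluoro-2-methoxyphenyl, and the matching furan-2-yl swap gave no change at the digits printed from compound 1 to compound 4 (within the scatter) with 4-cyanobenzyl in place. The four compounds therefore close a square in which the change carried from one core to the other without any difference in size, though this covers these two cores only. It does not show that the change itself shifts the number, as each of these steps lies within the scatter, so what carried over cannot be told from no effect at all, and nothing shown bears on what lies behind these numbers.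

The compounds shown leave open whether the agreement would persist with a longer chain linking the two amine nitrogens. They also leave open how a group such as a carboxylic acid in place of the nitrile would behave on either core.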